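Moving the sulfur one carbon along the acid chain

A few compounds are considered here, and "the series" means these few. Any claim that something is new, unique, unknown or untested is made for them only; others in the source may bear on it.

Compound 2: `CCCCC[C@H](O)/C=C/[C@H]1[C@H](O)CC(=O)[C@@H]1CSCCCCC(=O)O`, 91 nM
Compound 1: `COCc1cccc(C[C@H](O)/C=C/[C@H]2[C@H](O)CC(=O)[C@@H]2CCSCCCC(=O)O)c1`, 620 nM

For the measured compounds named here, in an assay on CHO cells for binding affinity to prostaglandin E2 receptor EP2 subtype (Mus musculus) (a higher number here means a weaker inhibitor, a lower number a stronger inhibitor), compound 2 gives the lower of the two numbers measured so far. Compound 1, whose number in this assay is higher, differs from compound 2 in more than one place, so its value shows only where a related compound lands and not what any single change does.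

Compound 3 is `CCCCC[C@H](O)/C=C/[C@H]1[C@H](O)CC(=O)[C@@H]1CCSCCCC(=O)O`. Its difference from compound 2 is ((3-carboxypropyl)sulfanyl)methyl in place of (4-carboxybutyl)sulfanyl on a saturated chain carbon bound to a saturated ring carbon; the two have the same atoms, joined differently. The sulfur thus sits one carbon further from the ring while the acid end stays the same number of atoms away from the ring carbon.

Going by the values given here, no measured pair isolates this change. Compound 1 carries the chain of compound 3 but also another omega chain, so it cannot be read as a step. Compound 3 is expected to land close to compound 2, with a modest weakening at most, the step from compound 2 to compound 3 being estimated as a 1.6-fold higher number from compound 2 to compound 3 (0.22 log units; within the scatter). Compound 3 is estimated at 150 nM in this assay, within 50 nM to 500 nM.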

Compound 3, inhibition constant: 75 nM
For compound 3 the middle estimate is 2.0-fold (0.30 log units) above the measured one; the range from low to high includes it.
By their numbers in this assay, from the lowest: compounds 3 and 2 (each within the scatter of the next); then compound 1.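

Exchanging (4-carboxybutyl)sulfanyl for ((3-carboxypropyl)sulfanyl)methyl on a saturated chain carbon bound to a saturated ring carbon gives a 1.2-fold lower number from compound 2 to compound 3 (0.08 log units; within the scatter), so this assay does not tell these two arrangements of the same atoms apart. For the compounds shown here, compound 3 also gives compound 1 a partner that differs in one place, and butyl in place of 3-(methoxymethyl)phenyl gives an 8.3-fold lower number from compound 1 to compound 3 (0.92 log units; beyond the scatter), the first reading of a single change at that end of the molecule. Of the two single changes now readable, only this second one lies beyond the scatter, and nothing measured here offers an explanation for either step.

From the compounds shown here alone, it remains open whether the sulfur can be replaced by an ether oxygen or a sulfone, or moved further along the acid chain, with the same outcome. Also open, going by these compounds, are how a longer chain or a tetrazole in place of the carboxylic acid would read, and whether 3-(methoxymethyl)phenyl on the chain of compound 2 would give a step like the one seen on the chain of compound 3.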